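This account rests on a few compounds, and the source may have more. Where it says the series, first, only, none or still open, it means among the compounds named here.

Compound 1: `COc1ccc(S(=O)(=O)Nc2cc(Cl)cc(Cl)c2)cc1N1CCNCC1` — 0.631 nM
Compound 2: `COc1ccc(S(=O)(=O)Nc2cc(Br)cc(Br)c2)cc1N1CCNCC1` — 0.501 nM
Compound 3: `COc1ccc(S(=O)(=O)Nc2cc(Cl)c(Cl)cc2Cl)cc1N1CCNCC1` — 5.01 nM

In an assay on isolated protein for binding affinity to 5-hydroxytryptamine receptor 6 (Homo sapiens) (a higher number here means a weaker inhibitor, a lower number a stronger inhibitor), compound 1 gives 0.631 nM, the second highest of the three numbers. The nearest measured step is a 1.3-fold lower number from compound 1 to compound 2 (0.10 log units; within the scatter); the furthest is a 7.9-fold higher number from compound 1 to compound 3 (0.90 log units; beyond the scatter). The unmeasured compound 4 is `COc1ccc(S(=O)(=O)Nc2cc(Br)cc(Br)c2Br)cc1N1CCNCC1`. It differs from compound 1 as follows: 2,3,5-tribromophenyl in place of 3,5-dichlorophenyl on a sulfonamide nitrogen. Two kinds of step bear on this. Exchanging chlorine for bromine, as in a 1.3-fold lower number from compound 1 to compound 2 (0.10 log units; within the scatter), stayed within the scatter. Adding a third halogen and changing the pattern, as in a 7.9-fold higher number from compound 1 to compound 3 (0.90 log units; beyond the scatter) and a 10-fold higher number from compound 2 to compound 3 (1.00 log units; beyond the scatter), gave a modest rise. Since compound 4 carries 2,3,5-tribromophenyl in place of the 3,5-dichlorophenyl of compound 1, a smaller rise than a 7.9-fold higher number from compound 1 to compound 3 (0.90 log units; beyond the scatter) is expected, giving a 3.2-fold higher number from compound 1 to compound 4 (0.50 log units; beyond the scatter). Compound 4 is therefore estimated at 2 nM, in the range 0.6 nM to 6.3 nM.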

Compound 4, inhibition constant: 2.51 nM
Compound 4: middle estimate off by 1.3-fold (0.10 log units), on the low side, and the stated range covers the measured number.
By their numbers in this assay, from the lowest: compounds 2 and 1 (each within the scatter of the next); then compounds 4 and 3 (each within the scatter of the next).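

In this assay, bromo in place of hydrogen on an aromatic carbon gave a 5.0-fold higher number from compound 2 to compound 4 (0.70 log units; beyond the scatter), so adding this one halogen to the 3,5-dibromophenyl group is enough to move the number beyond the scatter. The step of a 4.0-fold higher number from compound 1 to compound 4 (0.60 log units; beyond the scatter) agrees with this, and a 2.0-fold lower number from compound 3 to compound 4 (0.30 log units; within the scatter) places the two trihalogenated compounds together despite their different halogens and patterns. Among these four compounds, both trihalogenated groups give higher numbers than both dihalogenated ones. As far as these compounds go, whether a nitrile or an amine in place of that third halogen would behave alike remains open. No supporting evidence accounts for the rise.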